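Ethoxymethyl to Bromomethyl on a Shared Naphthalene-Free Core

A few compounds are considered here, and "the series" means these few. Any claim that something is new, unique, unknown or untested is made for them only; others in the source may bear on it.

Compound 2 `CCOCc1c(C)coc1-c1ccc2c(CC)cccc2c1OC` shares its core with compound 1 `CCc1cccc2c(OC)c(-c3occ(C)c3C(=O)NC)ccc12`. In a functional assay on A549 cells (Homo sapiens) for cytotoxicity, read by MTT assay, with a stated time of 72 h (on this read-out higher numbers stand for an effect only at larger amounts of compound and lower numbers for an effect already at smaller amounts), compound 1 reaches only a limit of > 10 ug/mL. In this assay compound 2 likewise reaches only a limit of > 10 ug/mL. The step from compound 1 to compound 2, in which ethoxymethyl replaces methylcarbamoyl on an aromatic carbon, is therefore a step that the two limits leave unreadable from compound 1 to compound 2; both values sit at the limit of > 10 ug/mL in this assay, at which 2 of the 2 values shown sit, so compound 2 stands at that limit with no number behind it.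

Compound 3 `CCc1cccc2c(OC)c(-c3occ(C)c3CBr)ccc12` differs from compound 2 by bromo in place of ethoxy on a saturated chain carbon bound to an aromatic carbon. Among the measured compounds shown here, only the one measured step bears on this change, and its size cannot be read, so no direction follows from it. The expectation for compound 3 is a step of an at least 1.2-fold lower number from compound 2 to compound 3 (0.09 log units; that floor lies within the scatter) in this assay, held with wide uncertainty. Compound 3 is estimated at 8 ug/mL, within a range from 2 ug/mL to 30 ug/mL.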

Compound 3, concentration for half-maximal effect: > 10 ug/mL
Compound 3: only a limit was reported; the forecaster's own chance of this, stated with the estimate: 45%; at least 1.2-fold (0.09 log units) between middle value and limit.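

In this assay compound 3 also reaches only a limit, > 10 ug/mL. Among the compounds shown here, no step among compound 1, compound 2 and compound 3 can therefore be read: the limit of > 10 ug/mL in this assay, at which 3 of the 3 values shown sit. The compounds shown leave open at what amount each would reach its half-maximal effect, and so whether methylcarbamoyl, ethoxymethyl or bromomethyl makes any difference.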